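Dimethylphenyl Amide Measured Against Its Chlorophenyl Counterpart

The source may report more compounds than this note shows. Statements on the series, on what has been measured and on what is new or still open speak of the compounds shown alone.

Three amides built on one shared core have been measured in a functional assay on the whole organism (Ear) for inhibition, with Mus musculus as the target, at a dose of 40 mg/kg by the oral route; on this read-out lower numbers stand for less inhibition and higher numbers for more inhibition at the one dose given (going by the name of the read-out). Compound 1 `CC(=O)Oc1ccc(-c2ccc(F)cc2F)cc1C(=O)Nc1ccccc1` gives 23.2% in this assay. Compound 2 `CC(=O)Oc1ccc(-c2ccc(F)cc2F)cc1C(=O)Nc1cccc(C)c1` gives 12.8%, and compound 3 `CC(=O)Oc1ccc(-c2ccc(F)cc2F)cc1C(=O)Nc1ccccc1Cl` gives 41.4%. Compound 3 thus stands highest of the three numbers: the step of a number 18.2 percentage points higher from compound 1 to compound 3 (beyond the scatter) and the step of a number 28.6 percentage points higher from compound 2 to compound 3 (beyond the scatter) both reach beyond the scatter.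

Compound 4 `CC(=O)Oc1ccc(-c2ccc(F)cc2F)cc1C(=O)Nc1cc(C)ccc1C` is the next member and has not yet been measured. It differs from compound 3 in one place: 2,5-dimethylphenyl in place of 2-chlorophenyl on an amide-type nitrogen. Among the compounds with values here, two measured steps bear on this change. The step of a number 28.6 percentage points higher from compound 2 to compound 3 (beyond the scatter) shows how much the 2-chlorophenyl group added relative to a methyl-bearing ring, while the step of a number 10.4 percentage points lower from compound 1 to compound 2 (beyond the scatter) shows that methyl in place of hydrogen on an aromatic carbon lowered the number. Compound 4 carries the 2,5-dimethylphenyl group and no chloro, so the expected direction is downward from compound 3, beyond the scatter and back toward the numbers of compound 1 and compound 2. The step expected is a number 21.4 percentage points lower from compound 3 to compound 4 (beyond the scatter). Compound 4 is therefore estimated at 20%, within a range from 5% to 38%.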

Compound 4, a percentage reported as inhibition, in the whole organism at one dose (the size of the read-out at that dose, not a potency): 22%
Estimate against measurement, compound 4: 2 percentage points below; measured number inside the range.
By their numbers in this assay, from the lowest: compounds 2, 4 and 1 (each within the scatter of the next, the first and the last beyond it); then compound 3.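

In this assay the change from 2-chlorophenyl to 2,5-dimethylphenyl on the amide-type nitrogen gives a number 19.4 percentage points lower from compound 3 to compound 4 (beyond the scatter) and so loses what the chloro-bearing ring had gained, showing that a ring with a methyl group in the 2,5-dimethylphenyl arrangement does not carry that gain. Within the data shown here, the two other new comparisons do not separate compound 4 from its neighbours: methyl in place of hydrogen gives a number 9.2 percentage points higher from compound 2 to compound 4 (within the scatter) and 2,5-dimethylphenyl in place of phenyl gives a number 1.2 percentage points lower from compound 1 to compound 4 (within the scatter), so at this position the second methyl and the pair of methyl groups cannot be told apart from the rings they replace, unlike the single methyl step a number 10.4 percentage points lower from compound 1 to compound 2 (beyond the scatter) that goes beyond the scatter. Among these four compounds, compound 3 alone stands apart from all the others, although the gap between compound 1 and compound 2 also lies beyond the scatter, and nothing given here accounts for these differences.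

The compounds shown leave open whether the rise belongs to chloro in particular or would also appear with a bromo or methoxy group on the amide's phenyl ring. They also leave open whether the same order of these rings would hold if the acetate on the shared core gave way to a free hydroxyl.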